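Cyclohexyl for sec-butyl on the amine nitrogen: series notes

The compounds below may be only part of what the source reports. "The series", "measured", "known", "first", "only" and "open" are said of these compounds alone.

Compound 1 `CCC(C)NC(=C\C(=O)/C=C/c1ccc(O)c(OC)c1)/C=C/c1ccc(O)c(OC)c1` carries a sec-butyl group on the amine nitrogen. In an ADME assay on EA.hy 926 cells (Homo sapiens) for inhibition, read by sulforhodamine B assay, with a stated time of 72 h (a lower number here means a stronger inhibitor, a higher number a weaker inhibitor), compound 1 gives only a limit, > 25000 nM. Compound 2 `COc1cc(/C=C/C(=O)/C=C(/C=C/c2ccc(O)c(OC)c2)NC2CCCCC2)ccc1O` differs from it by cyclohexyl in place of sec-butyl on an amine nitrogen. In this assay compound 2 likewise gives only a limit, > 25000 nM. The step that the two limits leave unreadable from compound 1 to compound 2 therefore cannot be read, as the limit of > 25000 nM in this assay, at which 3 of the 3 values shown sit, makes plain. Compound 3 `CCC(C)NC(=C\C(=O)/C=C/c1ccc(O)cc1)/C=C/c1ccc(O)cc1` has a different core; the difference between the two cores is not broken down here. In this assay compound 3 also returns only a limit, > 25000 nM. Compound 4 `O=C(/C=C(/C=C/c1ccc(O)cc1)NC1CCCCC1)/C=C/c1ccc(O)cc1`, not yet measured, differs from compound 3 by cyclohexyl in place of sec-butyl on an amine nitrogen, the same change as made from compound 1 to compound 2, at the same place. Within the data shown here, with every value so far sitting at the limit described by the limit of > 25000 nM in this assay, at which 3 of the 3 values shown sit, no readable step is available to guide the expectation, and the change itself gave no readable step from compound 1 to compound 2. The step that the limit leaves unreadable from compound 3 to compound 4 is therefore expected to be unreadable in the same way. Compound 4 is expected to give about 40000 nM in this assay. The expected range for compound 4 runs from 20000 nM to 150000 nM.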

Compound 4, half-maximal inhibitory concentration: 4200 nM
Compound 4: middle estimate off by 9.5-fold (0.98 log units), on the high side; the whole stated range lies above it.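

On the core of compound 3, cyclohexyl in place of sec-butyl on an amine nitrogen gives an at least 5.9-fold lower number from compound 3 to compound 4 (0.77 log units; beyond the scatter) in this assay, and since compound 3 is only a limit, this step is a minimum and not an exact size. Among these compounds, on the core of compound 1 the same change cannot be read, so the series offers only one readable instance of it, and the values at the limit give no second step to set beside it: the limit of > 25000 nM in this assay, at which 3 of the 4 values shown sit. The result therefore shows that the change can lower the number on one core, but it does not show that the effect carries over to the core of compound 1, nor that it differs between the two cores.

The compounds shown leave open how far the number falls on the core of compound 3, and whether any group on the amine nitrogen brings the core of compound 1 to a readable value. On these data alone, it also remains open whether ring size matters, as a cyclopentyl group or a longer chain at that nitrogen would test.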